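A few compounds are considered here, and "the series" means these few. Any claim that something is new, unique, unknown or untested is made for them only; others in the source may bear on it.

Compound 1 `COc1ccc(-c2nc(SCC(=O)c3sc(-c4ccccc4)nc3C)[nH]c(=O)c2C#N)cc1`: 97.3%
Compound 2 `COc1cccc(-c2nc(SCC(=O)c3sc(-c4ccccc4)nc3C)[nH]c(=O)c2C#N)c1`: 99%
Compound 3 `Cc1nc(-c2ccc(Cl)cc2)sc1C(=O)CSc1nc(-c2ccc(Cl)c(Cl)c2)c(C#N)c(=O)[nH]1`: 101%

All three were tested in a functional assay on U-87MG ATCC cells for antiproliferative activity against U-87 MG (Homo sapiens), read by MTT assay, with a stated time of 48 h, tested at 5 uM; a lower number here means a stronger effect, a higher number a weaker effect of the compound at the concentration tested. In this assay compound 3 gives 101%, compound 2 gives 99% and compound 1 gives 97.3%. Compound 3 sits together with compound 2 and compound 1 inside the usual scatter, so none of the three can be told apart, and all of them leave the cells close to fully viable at the tested concentration.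

Compound 4 `Cc1nc(-c2ccccc2)sc1C(=O)CSc1nc(-c2ccc(Cl)c(Cl)c2)c(C#N)c(=O)[nH]1` differs from compound 3 by one change: hydrogen in place of chloro on an aromatic carbon. Among the measured compounds shown here, the only measured step, a number 1.7 percentage points higher from compound 1 to compound 2 (within the scatter), concerns a methoxyphenyl on the other end of the shared core and was itself within the scatter; no measured step touches the chlorophenyl that changes here. On this basis a step beyond the scatter is not expected, and a number 2 percentage points lower from compound 3 to compound 4 (within the scatter) is the estimated movement. Compound 4 is therefore expected to give about 99% in this assay, within a range from 90% to 108%.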

Compound 4, a percentage reported as activity, at one concentration (the size of the read-out at that concentration, not a potency): 98.6%
Estimate against measurement, compound 4: 0.4 percentage points above, within the range that was stated.
By their numbers in this assay, from the lowest: compounds 1, 4, 2 and 3 (each within the scatter of the next).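

In this assay, among the compounds shown here, the chloro on the 4-chlorophenyl is exchanged for hydrogen for the first time, and the result is a number 2.4 percentage points lower from compound 3 to compound 4 (within the scatter) so that 4-chlorophenyl and phenyl cannot be told apart at this position. At the other end of the shared core, 3,4-dichlorophenyl can now be set against both methoxyphenyl groups, with a number 0.4 percentage points lower from compound 2 to compound 4 (within the scatter) for one and a number 1.3 percentage points higher from compound 1 to compound 4 (within the scatter) for the other, so this second position also shows no readable change. No measurement is available that would explain why these compounds read alike.

Both positions have so far been probed only with chloro, methoxy or hydrogen on a phenyl ring, all leaving the cells close to fully viable. From the compounds shown here alone, whether an amine or a carboxylic acid in place of the chloro would move the number beyond the scatter remains open.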